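The compounds below may be only part of what the source reports. "The series", "measured", "known", "first", "only" and "open" are said of these compounds alone.

Of the compounds shown here, three built on one shared core have been tested in a functional assay on the whole organism for inhibition, with Nicotiana tabacum as the target; a higher number here means a weaker inhibitor, a lower number a stronger inhibitor. Compound 1 `Cc1nc(Nc2ccccc2)c2cc[nH]c2n1` gives 550000000 nM. Compound 2 `Cc1nc(Nc2ccc(Cl)cc2)c2cc[nH]c2n1`, which carries chloro in place of hydrogen on an aromatic carbon, gives 224000000 nM; the step of a 2.5-fold lower number from compound 1 to compound 2 (0.39 log units; beyond the scatter) is modest but beyond the usual scatter. Compound 3 `COc1ccc(Nc2[nH]c(C)nc3nccc2-3)cc1` gives 661000000 nM in this assay. Its number and that of compound 1 lie within the usual scatter of each other, so the two cannot be told apart; only compound 2 sits clearly apart from compound 3, with the lower number of the pair.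

Compound 4 `Cc1nc2nccc-2c(Nc2ccc(C(C)C)cc2)[nH]1` has not yet been measured. It differs from compound 3 by isopropyl in place of methoxy on an aromatic carbon. Within the data shown here, no measured step swaps methoxy for isopropyl, so nothing bears on this change directly. Among the measured compounds shown here, the one measured step, a 2.5-fold lower number from compound 1 to compound 2 (0.39 log units; beyond the scatter), shows that changing the group on that aromatic carbon can move the number modestly. A modest move toward a lower number, or none beyond the scatter, is expected, which is estimated as a 1.7-fold lower number from compound 3 to compound 4 (0.22 log units; within the scatter). Compound 4 is therefore expected to give about 400000000 nM in this assay, within a range from 150000000 nM to 1000000000 nM.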

Compound 4, half-maximal inhibitory concentration: 45700000 nM
Beside the measured number, compound 4's estimate is 8.8-fold (0.94 log units) above it, outside the stated range (below it).
By their numbers in this assay, from the lowest: compound 4; then compound 2; then compounds 1 and 3 (each within the scatter of the next).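

In this assay the swap of methoxy for isopropyl brings a 14-fold lower number from compound 3 to compound 4 (1.16 log units; beyond the scatter) and so shows that the group on this aromatic carbon, para to a large group, can move the number much further than the modest step of a 2.5-fold lower number from compound 1 to compound 2 (0.39 log units; beyond the scatter) had revealed. The change replaces a group holding one hydrogen-bond acceptor with a slightly larger one holding none, but a single pair of compounds cannot show whether either difference matters. Nothing available here accounts for the size of this step.

From the compounds shown here alone, whether the number would fall further with a tert-butyl group or a longer chain at this place remains open. So does what an amine or a carboxylic acid would do there.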